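The source may report more compounds than this note shows. Statements on the series, on what has been measured and on what is new or still open speak of the compounds shown alone.

Working notes on the series. Compound 1 `COc1cc(-c2nnc(SC)n2/N=C/c2ccccc2)cc(OC)c1OC` carries a methylsulfanyl group and an unsubstituted phenyl on the carbon with a double bond to nitrogen. In a functional assay on HepG2 cells (Homo sapiens) for cytotoxicity, read by MTT assay, with a stated time of 48 h (on this read-out higher numbers stand for weaker inhibition and lower numbers for stronger inhibition), compound 1 gives > 200000 nM, which is a limit of the assay and not a number. Compound 2 `COc1cc(-c2nnc(SCc3ccc(F)cc3)n2/N=C/c2ccccc2)cc(OC)c1OC` differs only at the sulfur-bound chain carbon. In this assay compound 2 gives > 200000 nM, again a limit. Compound 3 `COc1ccc(/C=N/n2c(SC)nnc2-c2cc(OC)c(OC)c(OC)c2)c(OC)c1` instead varies the aryl on the imine carbon. In this assay compound 3 gives > 200000 nM, also a limit. Going by the values given here, compound 3 thus stands at the upper limit, where all values so far sit (the limit of > 200000 nM in this assay, at which 3 of the 3 values shown sit).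

The change from compound 3 to the unmeasured compound 4 `COc1ccc(/C=N/n2c(SCc3ccc(F)cc3)nnc2-c2cc(OC)c(OC)c(OC)c2)c(OC)c1` is 4-fluorophenyl in place of hydrogen on a saturated chain carbon bound to a sulfur. Two measured steps could bear on it. The same replacement at the sulfur-bound chain carbon, from compound 1 to compound 2, gave a step that the two limits leave unreadable from compound 1 to compound 2. The step from compound 1 to compound 3 gave a step that the two limits leave unreadable from compound 1 to compound 3. Neither is readable, so no size or direction can be taken from them; the expectation is simply that compound 4 stays where the others sit.

Compound 4 is expected in this assay at 200000 nM, within 100000 nM to 400000 nM, most likely again reported only as a limit. The step from compound 3 to compound 4 is expected to be a number no higher from compound 3 to compound 4 (the limit leaves the size open), none beyond the scatter.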

Compound 4, half-maximal inhibitory concentration: > 200000 nM
Compound 4: a limit, no number; the forecaster's own chance of this, stated with the estimate: 85%; the middle value sits exactly at the limit.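

In this assay compound 4 gives > 200000 nM, again a limit of the assay and not a number. No new step can be read, neither from compound 3 to compound 4 nor from compound 2 to compound 4: the limit of > 200000 nM in this assay, at which 4 of the 4 values shown sit. The compounds shown leave open whether the 4-fluorophenyl or the 2,4-dimethoxyphenyl change has any effect on this read-out, in either direction.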